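Cyclopentyl for cyclohexyl on the amide nitrogen of compound 2

A few compounds are considered here, and "the series" means these few. Any claim that something is new, unique, unknown or untested is made for them only; others in the source may bear on it.

All values here come from a functional assay on MCF7 cells (Homo sapiens) for inhibition; on this read-out lower numbers stand for stronger inhibition and higher numbers for weaker inhibition. Compound 1 `CCC(C)C(NC(=O)n1nnc2ccccc21)C(=O)NC1CCCCC1` gives 63100 nM in this assay. Compound 2 `CC(C)C(NC(=O)NO)C(=O)NC1CCCCC1` reaches only a limit of this assay, > 100000 nM, which is not a number. Compound 3 `CCC(C)C(NC(=O)NO)C(=O)NC1CCCCC1` likewise reaches only a limit of this assay, > 100000 nM. Both sit at the limit of > 100000 nM in this assay, at which 2 of the 3 values shown sit. For the measured compounds named here, the single step between measured compounds differing in one place, a step that the two limits leave unreadable from compound 2 to compound 3, therefore has no readable size.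

Compound 2 thus stands at the limit of this assay with no measured number of its own. Of the three values shown, two are limits, and compound 1 alone carries a number.

Compound 4 `CC(C)C(NC(=O)NO)C(=O)NC1CCCC1` differs from compound 2 in one place: cyclopentyl in place of cyclohexyl on an amide-type nitrogen. No measured step touches the ring on the amide-type nitrogen, and the only step in the series is unreadable, so nothing shown bears directly on this change. The expectation rests on compound 2 alone, which sits at > 100000 nM. Compound 4 is expected to stay at or near that limit, and the step that the limit leaves unreadable from compound 2 to compound 4 is expected to be none beyond the scatter. Compound 4 is estimated at 150000 nM, within 50000 nM to 500000 nM, most likely again reported only as a limit of this assay.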

Compound 4, half-maximal inhibitory concentration: > 100000 nM
Compound 4: a limit, no number (the forecaster's own chance of this, stated with the estimate: 75%); the middle value lies beyond the limit too.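

No new step can be read between compound 2 and compound 4, since each carries only a limit and no number in this assay: the limit of > 100000 nM in this assay, at which 3 of the 4 values shown sit.

The compounds shown leave open whether cyclopentyl and cyclohexyl on the amide-type nitrogen differ at all in inhibition, and how far either compound lies from that limit.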